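Bromine for methyl on the ester-bearing ring: cytotoxicity outlook

The compounds below may be only part of what the source reports. "The series", "measured", "known", "first", "only" and "open" are said of these compounds alone.

Measured so far:
compound 1 `C=C(CCc1cc(O)c2c(=O)cc(-c3ccccc3)oc2c1)Cc1c(Br)cccc1C(=O)CC` — 379000 nM
compound 2 `COC(=O)c1ccc(C)cc1OC(=O)COc1cc(O)c2c(=O)cc(-c3ccccc3)oc2c1` — 250000 nM
compound 3 `COC(=O)c1cccc(OC)c1OC(=O)COc1cc(O)c2c(=O)cc(-c3ccccc3)oc2c1` — 196000 nM

In an ADME assay on cells (T-cell, Mus musculus, strain BALB/c) for cytotoxicity, read by MTT assay, with a stated time of 48 h (a lower number here means that less compound is tolerated, a higher number that more compound is tolerated), compound 1 gives 379000 nM, compound 2 gives 250000 nM and compound 3 gives 196000 nM. Compound 2 sits second highest of the three numbers, but its gap to compound 3 and its gap to compound 1 both lie within the usual scatter, so no order among the three can be read from these values; all three compounds share the same core and are tolerated at a similar level.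

Compound 4 `COC(=O)c1c(Br)cccc1OC(=O)COc1cc(O)c2c(=O)cc(-c3ccccc3)oc2c1` is not yet measured. It differs from compound 2 as follows: a group of 11 heavy atoms (8 carbon, 2 oxygen, 1 bromine; one six-membered aromatic ring of carbon only) in place of a group of 11 heavy atoms (9 carbon, 2 oxygen; one six-membered aromatic ring of carbon only), on an oxygen next to a carbonyl group. The shared core and the ester linkage are untouched; only a group on the outer aromatic ring changes, one containing bromine in place of one containing an extra carbon.

Among the measured compounds shown here, with no step between measured compounds available, the expectation for this assay rests on the narrow spread of the three numbers. Since compounds 1 to 3 differ far more from one another than compound 4 does from compound 2 and still fall together, the step from compound 2 to compound 4 is expected to be a 1.1-fold lower number from compound 2 to compound 4 (0.04 log units; within the scatter), none beyond the scatter in either direction. Compound 4 is therefore estimated at 230000 nM, within a range of 110000 nM to 480000 nM.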

Compound 4, half-maximal cytotoxic concentration: 388000 nM
Estimate against measurement, compound 4: 1.7-fold (0.23 log units) below, and the stated range covers the measured number.
By their numbers in this assay, from the lowest: compounds 3, 2, 1 and 4 (each within the scatter of the next).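

In this assay, among the compounds shown here, the exchange on an oxygen next to a carbonyl group, where the outer aromatic group of 11 heavy atoms with 9 carbon gives way to one of 11 heavy atoms with 8 carbon and 1 bromine, amounts to a 1.6-fold higher number from compound 2 to compound 4 (0.19 log units; within the scatter) and is the first one-place step available. This step stays within the scatter, so the bromine-bearing group and the all-carbon group cannot be told apart at this place in this read-out, while both carry the same counts of hydrogen-bond donors and acceptors. No measurement on hand speaks to what lies behind this result.

The compounds shown leave open whether a more different group at this place, such as a carboxylic acid or an amine on the outer aromatic ring, would produce a step beyond the scatter. For the compounds shown here, they also leave open whether the bromine-for-carbon exchange would read the same with a longer chain in place of the methyl ester, since every one-place comparison so far rests on the single pair of compound 2 and compound 4.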